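The compounds below may be only part of what the source reports. "The series", "measured", "known", "first", "only" and "open" are said of these compounds alone.

Compound 1 `Cc1ccc(S(=O)(=O)n2cc(/C=N\c3ccc(N4CCOCC4=O)cc3)c3ccccc32)cc1` and compound 2 `O=C1COCCN1c1ccc(/N=C\c2cn(C(=O)c3ccccc3)c3ccccc23)cc1` share one core and differ only in the group on the aromatic nitrogen. In an ADME assay on BV-2 cells (Mus musculus) for cytotoxicity, read by MTT assay, with a stated time of 48 h, tested at 1 uM (on this read-out higher numbers stand for a weaker effect at the one concentration tested and lower numbers for a stronger effect), compound 1 gives 92.1%, the lower of the two numbers shown, and compound 2 gives 109%. Within the data shown here, the single measured step, a number 16.9 percentage points higher from compound 1 to compound 2 (beyond the scatter), is the only guide available. Compound 3 `O=C1COCCN1c1ccc(/N=C\c2cn(C(=O)c3ccc(Cl)cc3)c3ccccc23)cc1` differs from compound 1 by (4-chlorophenyl)carbonyl in place of (4-methylphenyl)sulfonyl on an aromatic nitrogen. Among the measured compounds shown here, this change runs parallel to the measured one: a carbonyl-linked aryl group again replaces the sulfonyl-linked one, with only a chlorine added on the entering ring, and no measured pair shows what that chlorine alone does. Compound 3 is therefore expected to move upward from compound 1 by a step of about a number 12.9 percentage points higher from compound 1 to compound 3 (beyond the scatter), of roughly the size seen for compound 2. Compound 3 is estimated at 105%, with a range from 90% to 120%.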

Compound 3, a percentage reported as activity, at one concentration (the size of the read-out at that concentration, not a potency): 97.6%
Compound 3: middle estimate off by 7.4 percentage points, on the high side, within the range that was stated.
By their numbers in this assay, from the lowest: compounds 1 and 3 (each within the scatter of the next); then compound 2.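

In this assay, the change on the aromatic nitrogen gives a number 5.5 percentage points higher from compound 1 to compound 3 (within the scatter) and so no longer separates the two compounds, which shows that replacing (4-methylphenyl)sulfonyl with a carbonyl-linked aryl group does not by itself carry a step beyond the scatter. The ring on that carbonyl also counts at this position, as chloro in place of hydrogen on an aromatic carbon gives a number 11.4 percentage points lower from compound 2 to compound 3 (beyond the scatter) in the same read-out. No measurement offered here accounts for either step.

The compounds shown leave open whether another group on that ring, such as methoxy or a primary amine, would move the number as chloro does. They also leave open whether a small acetyl group on the aromatic nitrogen would behave like benzoyl.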